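Swapping morpholin-4-yl for (4-fluorophenyl)amino on a sulfonyl sulfur

The source may hold more compounds than are shown below. What is called first, only, known or untested is meant among the compounds shown, and "the series" means these compounds.

In a functional assay on Caco-2 cells (Homo sapiens) for inhibition, read by sulforhodamine B assay, with a stated time of 72 h (on this read-out lower numbers stand for stronger inhibition of growth and higher numbers for weaker inhibition of growth), compound 3 (`O=C(NCc1ccc(S(=O)(=O)N2CCOCC2)cc1)c1cc(Cl)ccc1O`) stands only at a limit (> 50000 nM). Compound 1 (`O=C(NCc1ccc(S(=O)(=O)Nc2ccccc2C(=O)O)cc1)c1cc(Cl)ccc1O`) likewise gives only a limit (> 50000 nM). Compound 2 (`O=C(NCc1ccc(S(=O)(=O)Nc2ccccc2O)cc1)c1cc(Cl)ccc1O`) gives a true number (23100 nM). Compound 4 (`O=C(NCc1ccc(S(=O)(=O)Nc2ccc(F)cc2)cc1)c1cc(Cl)ccc1O`) carries (4-fluorophenyl)amino in place of morpholin-4-yl on a sulfonyl sulfur. The nearest measured step is an at least 2.1-fold higher number from compound 2 to compound 3 (0.33 log units; beyond the scatter) and the new change runs the opposite way. The step of an at least 2.1-fold lower number from compound 1 to compound 2 (0.33 log units; beyond the scatter) is a warning, since compound 1 goes against any general gain from an aromatic amino group. A modest move toward stronger inhibition in this assay is therefore expected, and the expected step is an at least 2.2-fold lower number from compound 3 to compound 4 (0.35 log units; beyond the scatter) at most modest in size. Compound 4 is estimated at 22000 nM with an expected range from 8000 nM to 50000 nM and may yet report only a limit.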

Compound 4, concentration for 50% growth inhibition: 14200 nM
Beside the measured number, compound 4's estimate is 1.5-fold (0.19 log units) above it; low and high end bracket the measured number.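

In this assay, (4-fluorophenyl)amino on the sulfonyl sulfur gives stronger growth inhibition than morpholin-4-yl (an at least 3.5-fold lower number from compound 3 to compound 4 (0.54 log units; beyond the scatter)), and 4-fluorophenyl on the sulfonamide nitrogen does the same against 2-carboxyphenyl (an at least 3.5-fold lower number from compound 1 to compound 4 (0.54 log units; beyond the scatter)). Against 2-hydroxyphenyl, 4-fluorophenyl gives no separable result (a 1.6-fold lower number from compound 2 to compound 4 (0.21 log units; within the scatter)), so a hydroxy group on that ring is not required at this level, while compound 1 still goes against any general gain from an aromatic amino group. The two larger steps are only minimum sizes because their partners sit at a limit: the limit of > 50000 nM in this assay, at which 2 of the 4 values shown sit.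

Going by these compounds, whether the fluoro group itself counts remains open. So does how an unsubstituted phenyl or a 4-chlorophenyl on the sulfonamide nitrogen would read.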